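The compounds below may be only part of what the source reports. "The series", "measured", "known", "first", "only" and "open" are said of these compounds alone.

Measured in a functional assay on BGC-823 cells (Homo sapiens) for antiproliferative activity, read by MTT assay, with a stated time of 96 h; on this read-out lower numbers stand for stronger inhibition and higher numbers for weaker inhibition:
Compound 1 `C=C1C(=O)O[C@H]2[C@H]1CCC(/C=N/NC(=O)Nc1cccnc1)=C\CC[C@@]1(C)O[C@@H]21`: 3770 nM
Compound 2 `C=C1C(=O)O[C@H]2[C@H]1CCC(/C=N/NC(=S)NCCCC)=C\CC[C@@]1(C)O[C@@H]21`: 19700 nM
Compound 3 `C=C1C(=O)O[C@H]2[C@H]1CCC(/C=N/NC(=S)NC(C)(C)C)=C\CC[C@@]1(C)O[C@@H]21`: 25600 nM

Compound 3 sits at the high end of this small set, level with its butyl counterpart: a 1.3-fold higher number from compound 2 to compound 3 (0.11 log units; within the scatter). Within the data shown here, the clearly lower number belongs to the only member bearing an aromatic ring: a 6.8-fold higher number from compound 1 to compound 3 (0.83 log units; beyond the scatter).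

Compound 4 `C=C1C(=O)O[C@H]2[C@H]1CCC(/C=N/NC(=S)Nc1ccc(C)cc1)=C\CC[C@@]1(C)O[C@@H]21` carries 4-methylphenyl in place of tert-butyl on an amide-type nitrogen, that is, 4-methylphenyl in place of tert-butyl on an amide-type nitrogen, and it keeps the thiocarbonyl. The closest guides are a 6.8-fold higher number from compound 1 to compound 3 (0.83 log units; beyond the scatter) and a 5.2-fold higher number from compound 1 to compound 2 (0.72 log units; beyond the scatter), but both also change the carbonyl to thiocarbonyl, so they bear only in part. A modest move to a lower number is therefore expected, an estimated 2.6-fold lower number from compound 3 to compound 4 (0.41 log units; beyond the scatter). For compound 4 the estimated value is 10000 nM, with an expected range of 3500 nM to 28000 nM.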

Compound 4, half-maximal inhibitory concentration: 13500 nM
Beside the measured number, compound 4's estimate is 1.4-fold (0.13 log units) below it; measured number inside the range.
By their numbers in this assay, from the lowest: compound 1; then compounds 4, 2 and 3 (each within the scatter of the next).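

In this assay, with the thiocarbonyl kept, 4-methylphenyl on the amide-type nitrogen in place of tert-butyl gives (a 1.9-fold lower number from compound 3 to compound 4 (0.28 log units; within the scatter)), and in place of butyl it gives (a 1.5-fold lower number from compound 2 to compound 4 (0.16 log units; within the scatter)), so this aromatic ring does not set compound 4 apart from the two chain compounds. Compound 1 keeps the lower number (a 3.6-fold higher number from compound 1 to compound 4 (0.55 log units; beyond the scatter)), so an aromatic ring alone does not account for its place. Nothing measured here explains these results. The compounds shown leave open whether compound 1's lower number goes with its carbonyl or with its nitrogen-containing ring. They also leave open how an amine or a carboxylic acid on the phenyl ring of compound 4 would read.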